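A few compounds are considered here, and "the series" means these few. Any claim that something is new, unique, unknown or untested is made for them only; others in the source may bear on it.

In an ADME assay on HFF cells (Homo sapiens) for cytotoxicity, read by MTT assay, with a stated time of 72 h (on this read-out lower numbers stand for stronger inhibition and higher numbers for weaker inhibition), compound 1 `CCCCCCCCCCc1cn(C[C@H](O)[C@H]2OC(=O)C(OCc3ccccc3)=C2OCc2ccccc2)nn1` reads > 100000 nM, which is a limit and not a number. Compound 2 `Cc1ccc(-c2cn(C[C@H](O)[C@H]3OC(=O)C(OCc4ccccc4)=C3OCc3ccccc3)nn2)cc1` reads > 100000 nM, also a limit. Within the data shown here, compound 3 `C[Si](C)(C)c1cn(C[C@H](O)[C@H]2OC(=O)C(OCc3ccccc3)=C2OCc2ccccc2)nn1`, at 20000 nM, holds the only actual number so far.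

Compound 4 `O=C1O[C@H]([C@@H](O)Cn2ccnn2)C(OCc2ccccc2)=C1OCc1ccccc1` differs from compound 3 by one change: a hydrogen atom in place of a group of 4 heavy atoms (3 carbon, 1 silicon; no ring), on an aromatic carbon. Among the measured compounds shown here, no measured step removes a group outright, so the evidence is indirect. For the measured compounds named here, two steps bear on it: an at least 5.0-fold lower number from compound 1 to compound 3 (0.69 log units; beyond the scatter) and an at least 5.0-fold lower number from compound 2 to compound 3 (0.69 log units; beyond the scatter). In both, a smaller group takes the place of a larger one on the aromatic carbon, and both sizes are bounded only by a limit. Going smaller again could suggest a lower number, but three compounds do not fix a direction for hydrogen. In this assay, only a small change is therefore expected, with no clear shift beyond the scatter: the expected result is a 1.5-fold higher number from compound 3 to compound 4 (0.18 log units; within the scatter). For compound 4 the estimate is 30000 nM, with an expected range of 8000 nM to 100000 nM.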

Compound 4, half-maximal inhibitory concentration: 610 nM
The estimate for compound 4 lay 49-fold (1.69 log units) above the measured number, outside the stated range (below it).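

Hydrogen on this aromatic carbon gives the lowest number of the four compounds in this assay, with a 33-fold lower number from compound 3 to compound 4 (1.52 log units; beyond the scatter), so even the group of 4 heavy atoms in compound 3 carries a large cost in this read-out. Against the two larger groups, the same replacement gives an at least 160-fold lower number from compound 2 to compound 4 (2.21 log units; beyond the scatter) and an at least 160-fold lower number from compound 1 to compound 4 (2.21 log units; beyond the scatter). Compound 1 and compound 2 both sit at a limit, so these two steps bound the size only from one side and the step between those two compounds cannot be read: the limit of > 100000 nM in this assay, at which 2 of the 4 values shown sit.

A methyl or an aminomethyl group on this carbon would show whether any group at all raises the number, or only groups as large as those shown. As far as these compounds go, whether the same order holds on a changed core also remains open.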